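Methylphenyl swap across a cytotoxicity series

The source may report more compounds than this note shows. Statements on the series, on what has been measured and on what is new or still open speak of the compounds shown alone.

Measured compounds in a functional assay on PC-3 cells (Homo sapiens) for cytotoxicity, read by MTT assay; a lower number here means a stronger inhibitor, a higher number a weaker inhibitor:
Compound 1, `COc1cc(/C=C/C(=O)c2sc(Nc3ccc(C)cc3)nc2C)cc(OC)c1OC`: in this assay compound 1 gives > 25000 nM, which is a limit of the assay and not a number.
Compound 2, `COc1cc(/C=C/C(=O)c2sc(Nc3ccccc3C)nc2C)cc(OC)c1OC`: in this assay compound 2 gives > 25000 nM, again a limit.
Compound 3, `Cc1ccc(Nc2nc(C)c(C(=O)/C=C/c3ccccc3Cl)s2)cc1`: in this assay compound 3 gives > 25000 nM, also a limit.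

Compound 1 and compound 2 differ by 2-methylphenyl in place of 4-methylphenyl on a nitrogen on an aromatic ring. Both values sit at a limit, so the step that the two limits leave unreadable from compound 1 to compound 2 cannot be read in either direction or in size. Compound 3 carries a different core; the difference between the core of compound 1 and the core of compound 3 is not broken down here.

Compound 4, `Cc1ccccc1Nc1nc(C)c(C(=O)/C=C/c2ccccc2Cl)s1`, has not yet been measured in this assay. It stands to compound 3 exactly as compound 2 stands to compound 1, by 2-methylphenyl in place of 4-methylphenyl on a nitrogen on an aromatic ring, the same change at the same place, since the two place descriptions agree word for word.

Among the measured compounds shown here, nothing measured so far separates any two compounds in this assay, because the limit of > 25000 nM in this assay, at which 3 of the 3 values shown sit, covers every value shown. On that footing the step that the limit leaves unreadable from compound 3 to compound 4 from compound 3 to compound 4 is expected to be unreadable as well. Compound 4 is therefore estimated at 40000 nM, within a range from 12000 nM to 200000 nM, and most probably the assay will again return only a limit.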

Compound 4, half-maximal inhibitory concentration: > 25000 nM
Compound 4 gave a limit, no number; the forecaster's own chance of this, stated with the estimate: 80%; the middle value is on the limit's open side.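

In this assay compound 4 gives > 25000 nM, a limit and not a number. With compound 3 also at a limit, no step can be read between compound 3 and compound 4, nor between compound 1 and compound 2. The compounds shown leave open whether 2-methylphenyl in place of 4-methylphenyl changes the result in this assay at all, since every value is censored: the limit of > 25000 nM in this assay, at which 4 of the 4 values shown sit.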